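Chalcone series: methoxy removal on the aryl ring

A few compounds are considered here, and "the series" means these few. Any claim that something is new, unique, unknown or untested is made for them only; others in the source may bear on it.

Compound 1 `COc1cccc(/C=C/C(=O)c2c(OC)cc(OC)cc2OCC=C(C)C)c1` gives 7700 nM in a functional assay on HCT-116 cells (Homo sapiens) for antiproliferative activity, read by sulforhodamine B assay, with a stated time of 48 h; a lower number here means a stronger inhibitor, a higher number a weaker inhibitor. Compound 2 `COc1cc(/C=C/C(=O)c2c(OC)cc(OC)cc2OCC=C(C)C)cc(OC)c1` gives 3500 nM in this assay; the change hydrogen in place of methoxy on an aromatic carbon produced a 2.2-fold higher number from compound 2 to compound 1 (0.34 log units; beyond the scatter). Compound 3 `COc1cc(OCC=C(C)C)c(C(=O)/C=C/c2cc(OC)c(OC)c(OC)c2)c(OC)c1CC=C(C)C` gives 4200 nM in this assay; its value and those of compound 2 and compound 1 lie close together, and the difference between the cores of compound 3 and compound 2 is not broken down here. Compound 4 `COc1ccc(/C=C/C(=O)c2c(OCC=C(C)C)cc(OC)c(CC=C(C)C)c2OC)cc1OC` is not yet measured. It differs from compound 3 by hydrogen in place of methoxy on an aromatic carbon; here the site is additionally ortho to a methoxy group, so this is the same kind of change as from compound 2 to compound 1, not the same. The step is expected to read a 1.9-fold higher number from compound 3 to compound 4 (0.28 log units; within the scatter), resting on the size of a 2.2-fold higher number from compound 2 to compound 1 (0.34 log units; beyond the scatter). Compound 4 is therefore estimated at 8000 nM, between 3500 nM and 18000 nM.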

Compound 4, half-maximal inhibitory concentration: 7400 nM
The estimate for compound 4 lay 1.1-fold (0.03 log units) above the measured number; the range from low to high includes it.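

In this assay hydrogen in place of methoxy on an aromatic carbon gives a 1.8-fold higher number from compound 3 to compound 4 (0.25 log units; within the scatter) and so does not clear the scatter on its own. The comparison rests on two pairs only and does not show that the step would hold on a core outside this series or at a different site on the ring. Within these two pairs, the size of the step carries from one core to the other with no difference that can be told apart: the same change on two cores in this assay, a 2.2-fold higher number (0.34 log units; beyond the scatter) from compound 2 to compound 1 and a 1.8-fold higher number (0.25 log units; within the scatter) from compound 3 to compound 4, 1.2-fold (0.10 log units) apart, within the scatter of two such steps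

The compounds shown leave open how an amine or a carboxylic acid in place of methoxy at this site would read. They also leave open whether a longer chain on the oxygen would change the size of the step.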